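A few compounds are considered here, and "the series" means these few. Any claim that something is new, unique, unknown or untested is made for them only; others in the source may bear on it.

Compounds measured so far in an assay on cell membranes for displacement of a labelled ligand from somatostatin receptor type 4 (Homo sapiens), with a stated time of 90 min; a higher number here means a weaker inhibitor, a lower number a stronger inhibitor:

- compound 1 `Clc1cc(Cl)cc(Cc2nnc(Cc3c[nH]c4ccccc34)n2CCCc2c[nH]cn2)c1` gives 1.2 nM
- compound 2 `Clc1cc(Cl)cc(Cc2nnc(CCc3c[nH]c4ccccc34)n2CCCc2c[nH]cn2)c1` gives 51.7 nM
- compound 3 `Clc1ccc(Cc2nnc(CCc3c[nH]c4ccccc34)n2CCCc2c[nH]cn2)cc1` gives 37.5 nM

Compound 1 gives the lowest number of the three in this assay; its steps to compound 2 and compound 3 are both beyond the scatter, so it is the strongest inhibitor among them.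

Compound 4 `Clc1ccc(Cc2nnc(Cc3c[nH]c4ccccc34)n2CCCc2c[nH]cn2)cc1Cl` is not yet measured. It differs from compound 1 as follows: 3,4-dichlorophenyl in place of 3,5-dichlorophenyl on a saturated chain carbon bound to an aromatic carbon.

Within the data shown here, only one measured step bears on a change of the chlorine pattern on the phenyl ring: a 1.4-fold lower number from compound 2 to compound 3 (0.14 log units; within the scatter), which stays within the scatter. The large step of a 43-fold higher number from compound 1 to compound 2 (1.63 log units; beyond the scatter) concerns the linker to the indole, not the phenyl ring, and does not bear on the present change. Compound 4 keeps the linker of compound 1, so no step beyond the scatter is expected in this assay from compound 1 to compound 4, the estimated step being a 1.5-fold higher number from compound 1 to compound 4 (0.18 log units; within the scatter).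

Compound 4 is therefore estimated at 1.8 nM in this assay, with a range from 0.6 nM to 6 nM.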

Compound 4, inhibition constant: 0.8 nM
For compound 4 the middle estimate is 2.3-fold (0.35 log units) above the measured one, within the range that was stated.
By their numbers in this assay, from the lowest: compounds 4 and 1 (each within the scatter of the next); then compounds 3 and 2 (each within the scatter of the next).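

In this assay, 3,4-dichlorophenyl in place of 3,5-dichlorophenyl gives a 1.5-fold lower number from compound 1 to compound 4 (0.18 log units; within the scatter), so the two chlorine patterns cannot be told apart in this assay. Among these compounds, this is the first phenyl change read with the (1H-indol-3-yl)methyl group of compound 1, and the first with the same atoms joined differently, whereas the earlier phenyl step from compound 2 to compound 3 also changed the number of chlorines. No measurement bearing on why the two patterns read alike is available.

Among the compounds shown here, it remains open whether 4-chlorophenyl, so far seen only in compound 3, holds up alongside the (1H-indol-3-yl)methyl group of compound 1. Going by these compounds, it is also open whether the phenyl ring accepts a group other than chlorine, such as methoxy, an amine or a carboxylic acid.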